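This account rests on a few compounds, and the source may have more. Where it says the series, first, only, none or still open, it means among the compounds named here.

Three compounds share one core and differ only in the saturated ring attached to its aromatic carbon. In an assay on Sf9 cells for inhibition of Leucine-rich repeat serine/threonine-protein kinase 2 (Homo sapiens), read by TR-FRET, with stated times of 30 min and 2 h (on this read-out higher numbers stand for weaker inhibition and lower numbers for stronger inhibition), compound 1 `O=C(Nc1ccnnc1)c1cc(N2CCNCC2)ccc1OCc1ccccc1` gives 15.9 nM. Compound 2 `O=C(Nc1ccnnc1)c1cc(N2CCC(CO)CC2)ccc1OCc1ccccc1` gives 20 nM in this assay, and compound 3 `O=C(Nc1ccnnc1)c1cc(N2CCC(O)CC2)ccc1OCc1ccccc1` gives 39.8 nM in this assay. Among the compounds with values here, compound 3 carries the largest of the three numbers, but only the step of a 2.5-fold higher number from compound 1 to compound 3 (0.40 log units; beyond the scatter) lies beyond the scatter; the step of a 2.0-fold higher number from compound 2 to compound 3 (0.30 log units; within the scatter) stays within it, so compound 2 and compound 3 are not separated by these data.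

Compound 4 `O=C(Nc1ccnnc1)c1cc(N2C[C@H]3COC[C@H]3C2)ccc1OCc1ccccc1` has not yet been measured. It differs from compound 3 as follows: a group of 8 heavy atoms (6 carbon, 1 nitrogen, 1 oxygen; 2 five-membered non-aromatic rings with 1 hetero atom each) in place of a group of 7 heavy atoms (5 carbon, 1 nitrogen, 1 oxygen; one six-membered non-aromatic ring with 1 hetero atom), on an aromatic carbon. The group that enters carries no hydrogen-bond donor, whereas the group that leaves carries one.

Within the data shown here, two measured steps bear on this change, a 2.5-fold higher number from compound 1 to compound 3 (0.40 log units; beyond the scatter) and a 2.0-fold higher number from compound 2 to compound 3 (0.30 log units; within the scatter). Both show that exchanging the ring on this aromatic carbon shifts the number only modestly, and neither involves a ring without a donor, so the direction for compound 4 is open. The step of a 1.2-fold lower number from compound 3 to compound 4 (0.09 log units; within the scatter) is expected to stay within the scatter. My estimate for compound 4 in this assay is 32 nM, with a range from 12 nM to 85 nM.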

Compound 4, half-maximal inhibitory concentration: 50.1 nM
Estimate against measurement, compound 4: 1.6-fold (0.19 log units) below; the range from low to high includes it.
By their numbers in this assay, from the lowest: compounds 1, 2, 3 and 4 (each within the scatter of the next, the first and the last beyond it).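

In this assay, the ring system of compound 4, which has no hydrogen-bond donor, is not separated from the 4-hydroxypiperidin-1-yl group (a 1.3-fold higher number from compound 3 to compound 4 (0.10 log units; within the scatter)), so this aromatic carbon accepts two five-membered rings in place of a six-membered ring without more than a small shift in the number. The same ring system is nevertheless set apart from both remaining groups, 4-(hydroxymethyl)piperidin-1-yl (a 2.5-fold higher number from compound 2 to compound 4 (0.40 log units; beyond the scatter)) and piperazin-1-yl (a 3.2-fold higher number from compound 1 to compound 4 (0.50 log units; beyond the scatter)), whereas compound 3 was separated only from compound 1; both steps are modest, so every ring shown here stays fairly close in this read-out. Nothing measured here accounts for these differences.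

Ring size, ring number and the hydrogen-bond donor all change together from compound 3 to compound 4, so the compounds shown cannot say which of these changes matters. From the compounds shown here alone, a 4-methoxypiperidin-1-yl group, which keeps the six-membered ring and replaces the hydroxy group with methoxy, could help separate them, and whether it would fall nearer compound 3 or compound 4 remains open.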